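Moving the chlorine: from compound 2 to compound 4

The source may report more compounds than this note shows. Statements on the series, on what has been measured and on what is new or still open speak of the compounds shown alone.

Values measured in a functional assay on GBM3 cells (Homo sapiens) for antiproliferative activity, read by WST assay, with a stated time of 72 h (on this read-out lower numbers stand for stronger inhibition and higher numbers for weaker inhibition), are these:
- compound 1 `O=C(Nc1ccc(C(F)(F)F)cc1)Nc1cc2ncncc2cc1OCc1cccc(F)c1` gives 6300 nM
- compound 2 `O=C(Nc1cc2ncncc2cc1OCc1ccc(Cl)cc1)Nc1cccc2ccccc12` gives 7700 nM
- compound 3 `O=C(Nc1ccc(Cl)c(Cl)c1)Nc1cc2ncncc2cc1OCc1cccc(F)c1` gives 2000 nM

Compound 2 at 7700 nM lies within the scatter of compound 1 at 6300 nM, so the two cannot be ranked. Compound 3 at 2000 nM shows a lower number than compound 2.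

Compound 4 `O=C(Nc1cc2ncncc2cc1OCc1ccccc1Cl)Nc1cccc2ccccc12` has not yet been measured. It differs from compound 2 by a single swap, (2-chlorophenyl in place of 4-chlorophenyl on a saturated chain carbon bound to an oxygen on an aromatic ring), in which 2-chlorophenyl takes the place of 4-chlorophenyl on a saturated chain carbon bound to an oxygen on an aromatic ring. The two have the same atoms, joined differently.

Among the measured compounds shown here, only one measured step is available, a 3.2-fold lower number from compound 1 to compound 3 (0.50 log units; beyond the scatter), and it is modest. It puts 3,4-dichlorophenyl in place of 4-(trifluoromethyl)phenyl on an amide-type nitrogen, which is a different place from the one changing here. For the measured compounds named here, no measured pair shows a chlorine shift of this kind, so that step suggests neither a size nor a direction. The estimate therefore starts from compound 2 at 7700 nM, and in this assay no step beyond the scatter is expected. The expected change is a 1.1-fold lower number from compound 2 to compound 4 (0.04 log units; within the scatter), with no direction favoured. For compound 4 the estimated value is 7000 nM, with an expected range from 2500 nM to 20000 nM.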

Compound 4, half-maximal inhibitory concentration: 2700 nM
For compound 4 the middle estimate is 2.6-fold (0.41 log units) above the measured one; the measured number falls inside the stated range.
By their numbers in this assay, from the lowest: compounds 3 and 4 (each within the scatter of the next); then compounds 1 and 2 (each within the scatter of the next).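

In this assay, the step of a 2.9-fold lower number from compound 2 to compound 4 (0.46 log units; beyond the scatter) shows that this position responds to a change that adds and removes no atoms: 2-chlorophenyl and 4-chlorophenyl have the same atoms, so where the chlorine sits on the ring is enough to move the number beyond the scatter. Among the compounds shown here, the only step measured earlier, a 3.2-fold lower number from compound 1 to compound 3 (0.50 log units; beyond the scatter), concerned the group on an amide-type nitrogen, so this is the first sign that the group on the saturated chain carbon bound to an oxygen on an aromatic ring also matters, and by a similarly modest amount. No measurement here bears on the reason for this shift.

As far as these compounds go, this is a single pair, so it remains open whether the same swap would give a step of this size if the amide-type nitrogen carried 3,4-dichlorophenyl or 4-(trifluoromethyl)phenyl. From the compounds shown here alone, it is also open how 3-chlorophenyl, a plain phenyl without chlorine, or a phenyl bearing an amine would compare at this position.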